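Swapping chloro for trifluoromethyl on compound 1

A few compounds are considered here, and "the series" means these few. Any claim that something is new, unique, unknown or untested is made for them only; others in the source may bear on it.

Compound 1 `Cc1ccccc1C(=O)Nc1sc2c(c1C(N)=O)CCN(C(=S)Nc1ccccc1Cl)C2`: 11000 nM
Compound 2 `COc1ccccc1C(=O)Nc1sc2c(c1C(N)=O)CCN(C(=S)Nc1ccccc1Cl)C2`: 20500 nM

Among the compounds with values here, in a functional assay on MKN-74 cells (Homo sapiens) for antiproliferative activity, with a stated time of 24 h (on this read-out higher numbers stand for weaker inhibition and lower numbers for stronger inhibition), compound 1 gives 11000 nM, and the only other measured compound cannot be ranked apart from it. Compound 3 `Cc1ccccc1C(=O)Nc1sc2c(c1C(N)=O)CCN(C(=S)Nc1ccccc1C(F)(F)F)C2` differs from compound 1 by trifluoromethyl in place of chloro on an aromatic carbon. No measurement covers this exchange. Within the data shown here, the one measured step, a 1.9-fold higher number from compound 1 to compound 2 (0.27 log units; within the scatter), is methoxy in place of methyl on an aromatic carbon, and it leaves the chloro untouched. With so little to go on, no change beyond the scatter is expected in this assay, and the expected step is a 1.1-fold higher number from compound 1 to compound 3 (0.04 log units; within the scatter). For compound 3 the estimated value is 12000 nM, with an expected range of 5000 nM to 30000 nM.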

Compound 3, half-maximal inhibitory concentration: 17400 nM
Estimate against measurement, compound 3: 1.5-fold (0.16 log units) below, and the stated range covers the measured number.
By their numbers in this assay, from the lowest: compounds 1, 3 and 2 (each within the scatter of the next).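

Trifluoromethyl is the first exchange shown at this place on the aromatic ring, ortho to a large group, where the earlier compounds all carry chloro. In this assay, it gives a 1.6-fold higher number from compound 1 to compound 3 (0.20 log units; within the scatter), so replacing one heavy atom with four leaves no change that can be told from the scatter. Nothing measured on these two groups speaks to the reason for this result.

As far as these compounds go, it remains open whether an amine or a carboxylic acid at this place would shift the number beyond the scatter. From the compounds shown here alone, it is also open whether trifluoromethyl in place of chloro would behave the same way on compound 2.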